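A Heteroaryl Swap at the Ortho Position, Half-Life Forecast

This account rests on a few compounds, and the source may have more. Where it says the series, first, only, none or still open, it means among the compounds named here.

Among the measured compounds shown here, compound 2 `Cc1noc(-c2c(F)cccc2-c2ccc([C@@H](C)Nc3nccc(Cl)c3NC(=O)CC#N)cc2)n1` stands highest of the two numbers so far in an in vivo ADME assay on the whole organism (strain Sprague-Dawley) for metabolic stability, with Rattus norvegicus as the target, at a dose of 2 mg/kg by the intravenous route (on this read-out lower numbers stand for a shorter-lived compound and higher numbers for a longer-lived compound), where compound 2 gives 8.8 h. For the measured compounds named here, its nearest neighbour is compound 1 `C[C@@H](Nc1nccc(Cl)c1NC(=O)CC#N)c1ccc(-c2cccc(F)c2C(F)(F)F)cc1`, which in this assay gives 1.8 h; the single measured step, a 4.9-fold higher number from compound 1 to compound 2 (0.69 log units; beyond the scatter), is the only one in this set. Compound 3 `C[C@@H](Nc1nccc(Cl)c1NC(=O)CC#N)c1ccc(-c2cccc(F)c2-c2nnn(C)n2)cc1` differs from compound 2 in one place: 2-methyl-2H-tetrazol-5-yl in place of 3-methyl-1,2,4-oxadiazol-5-yl on an aromatic carbon.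

Going by the values given here, only that one step bears on the position in question, and it shows that exchanging the group there can move the half-life well beyond the scatter. Among the compounds with values here, it involved trifluoromethyl giving way to a five-membered aromatic ring with 3 hetero atoms, whereas the present change replaces one five-membered aromatic ring with another, carrying 4 hetero atoms and one more hydrogen-bond acceptor; no measured pair covers a swap of this kind. The expected step is accordingly small, without a firm direction, and is estimated as a 1.3-fold lower number from compound 2 to compound 3 (0.10 log units; within the scatter). Compound 3 is therefore expected to give about 7 h in this assay, with a range from 3 h to 18 h.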

Compound 3, half-life: 7.8 h
Compound 3: the middle estimate sits 1.1-fold (0.05 log units) below what was measured, and the stated range covers the measured number.
By their numbers in this assay, from the lowest: compound 1; then compounds 3 and 2 (each within the scatter of the next).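

In this assay, 2-methyl-2H-tetrazol-5-yl in place of 3-methyl-1,2,4-oxadiazol-5-yl gives a 1.1-fold lower number from compound 2 to compound 3 (0.05 log units; within the scatter), so on this read-out the two rings cannot be told apart at this place, on an aromatic carbon ortho to a fluoro group, although the entering ring has 4 hetero atoms and 4 hydrogen-bond acceptors where the leaving ring has 3 of each. Measured against trifluoromethyl, the same tetrazolyl group gives a 4.3-fold higher number from compound 1 to compound 3 (0.64 log units; beyond the scatter), so among these three compounds the longer half-life seen with the oxadiazolyl group is no longer tied to that one ring but is shared by a second five-membered aromatic ring. Nothing available here accounts for either step.

The compounds shown leave open whether a five-membered aromatic ring is needed at all at this place, or whether an open-chain group such as a primary amide, an amine or a carboxylic acid would serve in the same way. They also leave open what the methyl group on each ring contributes, since both rings shown carry one.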